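A few compounds are considered here, and "the series" means these few. Any claim that something is new, unique, unknown or untested is made for them only; others in the source may bear on it.

Series notes. Values in an assay on isolated protein for inhibition of aldehyde dehydrogenase 1A1 (Homo sapiens), read by spectrophotometry, tested at 10 uM; on this read-out higher numbers stand for more inhibition at the one concentration tested (going by the name of the read-out) and lower numbers for less inhibition:
compound 1 `Cc1cccc(Cn2c(CN3CCN(C(=O)c4ccc([N+](=O)[O-])cc4)CC3)nc3ccccc32)c1`, compound 1 gives 24.3%
compound 2 `Cc1cccc(Cn2c(OC3CCN(C(=O)c4ccco4)CC3)nc3ccccc32)c1`, compound 2 gives 68.3%
compound 3 `CC(C)CCn1c(OC2CCN(C(=O)c3ccco3)CC2)nc2ccccc21`, compound 3 gives 30.8%

Compound 1 has the lowest of the three numbers. For the measured compounds named here, its nearest neighbour is compound 3, whose value lies within the scatter of that of compound 1; the value of compound 2 lies beyond the scatter, but compound 1 and compound 2 differ in more than one place and no single step joins them. Going by the values given here, the one step measured, a number 37.5 percentage points lower from compound 2 to compound 3 (beyond the scatter), concerns the group on the saturated chain carbon bound to the aromatic nitrogen and leaves the carbonyl-bearing aromatic ring untouched.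

Compound 4 `COc1ccc(C(=O)N2CCN(Cc3nc4ccccc4n3Cc3cccc(C)c3)CC2)cc1` is not yet measured. Against compound 1 it shows (methoxy in place of nitro on an aromatic carbon). Among the compounds with values here, no measured step bears on a change at this ring, so there is no basis for expecting a step in this assay beyond the scatter in either direction. Compound 4 is therefore estimated at 28%, with a range of 10% to 50%, which amounts to an expected step of a number 3.7 percentage points higher from compound 1 to compound 4 (within the scatter).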

Compound 4, a percentage reported as inhibition, at one concentration (the size of the read-out at that concentration, not a potency): 55.5%
The estimate for compound 4 lay 27.5 percentage points below the measured number; the whole stated range lies below it.
By their numbers in this assay, from the lowest: compounds 1 and 3 (each within the scatter of the next); then compound 4; then compound 2.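

In this assay, the place on the six-membered aromatic ring para to a large group proves responsive: methoxy in place of nitro gives a number 31.2 percentage points higher from compound 1 to compound 4 (beyond the scatter). For the compounds shown here, the earlier step concerned only the group on the chain carbon bound to the aromatic nitrogen, so this is the first sign that the aromatic ring on the carbonyl also moves the number beyond the scatter, here with the rest of compound 1 unchanged. No measurement to hand explains this step.

Still open, going by these compounds, is whether the step follows the departure of nitro or the arrival of methoxy; a plain hydrogen, an amine or a chlorine at this place would help separate the two. Also open, on these data alone, is whether the change would carry over to a 4-substituted phenyl carbonyl on the core of compound 2.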